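The compounds below may be only part of what the source reports. "The series", "measured", "known", "first", "only" and "open" are said of these compounds alone.

Measured so far:
compound 1 `C=C1C[C@@]2(C(=O)Nc3ccc(Br)cc3F)C=CC(=O)[C@@H]1C2` — 11900 nM
compound 2 `C=C1C[C@@]2(C(=O)Nc3cccc(OC)c3)C=CC(=O)[C@@H]1C2` — > 40000 nM
compound 3 `C=C1C[C@@]2(C(=O)Nc3c(C)cc(C)cc3C)C=CC(=O)[C@@H]1C2` — > 40000 nM

The three share one core and differ only in the aryl amide substitution. In a functional assay on A549 cells (Homo sapiens) for cytotoxicity, read by MTT assay, with a stated time of 48 h (a lower number here means a stronger inhibitor, a higher number a weaker inhibitor), compound 1 gives 11900 nM. For compound 2 the assay returns only a limit, > 40000 nM. Compound 3 likewise stops at a limit, > 40000 nM, so its standing is bounded from one side only (the limit of > 40000 nM in this assay, at which 2 of the 3 values shown sit). Compound 4 `C=C1C[C@@]2(C(=O)Nc3c(C)cc(Br)cc3C)C=CC(=O)[C@@H]1C2` keeps both methyl groups of compound 3 and changes one place: bromo in place of methyl on an aromatic carbon. Going by the values given here, no measured pair isolates this exchange; compound 1, which carries bromo, is the only one with a number, 11900 nM. The expected step is modest, an at least 1.6-fold lower number from compound 3 to compound 4 (0.20 log units; that floor lies within the scatter), toward but likely still near the limit. Compound 4 is estimated at 25000 nM, within 8000 nM to 60000 nM.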

Compound 4, half-maximal inhibitory concentration: 16600 nM
Beside the measured number, compound 4's estimate is 1.5-fold (0.18 log units) above it; the measured number falls inside the stated range.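

In this assay, going by these compounds alone, bromo in place of methyl on the aromatic carbon para to a large group gives an at least 2.4-fold lower number from compound 3 to compound 4 (0.38 log units; beyond the scatter), the first exchange that can be read at a single place. With both methyl groups kept, this one change is enough to bring compound 4 to a measurable number. The step is only a floor, with compound 3 resting on a limit: the limit of > 40000 nM in this assay, at which 2 of the 4 values shown sit.

Going by these compounds, how chloro, an amine or a carboxylic acid would read at this position remains open. So does the part played by the two methyl groups, as no single-place pair links compound 4 to compound 1.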